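The source may report more compounds than this note shows. Statements on the series, on what has been measured and on what is new or still open speak of the compounds shown alone.

Measured compounds in a functional assay on MOLT-4 cells (Homo sapiens) for antiproliferative activity; a lower number here means a stronger inhibitor, a higher number a weaker inhibitor:
- compound 1 `COc1ccc(-c2cc(N)c(C(=O)c3cc(OC)c(OC)c(OC)c3)s2)cc1OC`: 20 nM
- compound 2 `COc1cc(C(=O)c2sc(-c3ccc([N+](=O)[O-])cc3)cc2N)cc(OC)c1OC`: 110 nM
- compound 3 `COc1cc(C(=O)c2sc(-c3ccc(Cl)cc3)cc2N)cc(OC)c1OC`: 77 nM

Compound 1 has the lowest number of the three. The nearest is compound 3, reached by a 3.9-fold higher number from compound 1 to compound 3 (0.59 log units; beyond the scatter); the furthest is compound 2, reached by a 5.5-fold higher number from compound 1 to compound 2 (0.74 log units; beyond the scatter). Between those two, a 1.4-fold lower number from compound 2 to compound 3 (0.15 log units; within the scatter).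

Compound 4 `COc1cc(C(=O)c2sc(-c3ccc(Cl)c(Cl)c3)cc2N)cc(OC)c1OC` differs from compound 1 by 3,4-dichlorophenyl in place of 3,4-dimethoxyphenyl on an aromatic carbon. Going by the values given here, the steps that bear on this are those leaving the same group from compound 1, both modest rises, and the two replacement groups differ from each other only within the scatter. A rise of the same order is therefore expected for compound 4, a 3.5-fold higher number from compound 1 to compound 4 (0.54 log units; beyond the scatter). Compound 4 is estimated at 70 nM, with a range of 30 nM to 170 nM.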

Compound 4, half-maximal inhibitory concentration: 270 nM
Estimate against measurement, compound 4: 3.9-fold (0.59 log units) below, outside the stated range (above it).
By their numbers in this assay, from the lowest: compound 1; then compounds 3 and 2 (each within the scatter of the next); then compound 4.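

In this assay, the step to the 3,4-dichlorophenyl group is the largest seen at this position (a 14-fold higher number from compound 1 to compound 4 (1.13 log units; beyond the scatter)). Chloro in place of hydrogen on the 4-chlorophenyl ring raises the number further (a 3.5-fold higher number from compound 3 to compound 4 (0.54 log units; beyond the scatter)), and 3,4-dichlorophenyl also separates from 4-nitrophenyl (a 2.5-fold higher number from compound 2 to compound 4 (0.39 log units; beyond the scatter)). 3,4-Dimethoxyphenyl gives the lowest number of the four compounds and 3,4-dichlorophenyl the highest, so the shared placing alone does not set the level, and nothing available explains the difference.

Open is whether both methoxy groups are needed, since 4-methoxyphenyl and 3-methoxyphenyl rings do not appear among these compounds. From the compounds shown here alone, a 4-aminophenyl ring at this carbon also remains open.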